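A few compounds are considered here, and "the series" means these few. Any claim that something is new, unique, unknown or untested is made for them only; others in the source may bear on it.

Compound 1 `COc1cc(C(=O)NNC(=S)Nc2csc(-c3ccccc3)c2)cc(OC)c1OC` and compound 2 `COc1cc(OC)cc(C(=O)NNC(=S)Nc2csc(-c3ccccc3)c2)c1` share a core and differ in one place. In a functional assay on U-373MG ATCC cells (Homo sapiens) for inhibition, read by colorimetric assay and MTT assay, with a stated time of 72 h (a higher number here means a weaker inhibitor, a lower number a stronger inhibitor), compound 1 gives 44000 nM. In this assay compound 2 gives 40000 nM. The change between them is hydrogen in place of methoxy on an aromatic carbon and gives a 1.1-fold lower number from compound 1 to compound 2 (0.04 log units; within the scatter).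

Compound 3 `COc1ccc(-c2cc(Nc3nnc(-c4ccc(C)cc4)s3)cs2)cc1` is built on a different core; how its core differs from that of compound 1 is not broken down here. In this assay compound 3 gives only a limit, > 100000 nM, which is the limit of > 100000 nM in this assay, at which 1 of the 3 values shown sits.

Compound 4 `Cc1ccc(-c2nnc(Nc3csc(-c4ccccc4)c3)s2)cc1` is not yet measured. It differs from compound 3 by hydrogen in place of methoxy on an aromatic carbon. This is the same kind of change as that from compound 1 to compound 2, though the surroundings differ: in compound 1 the leaving methoxy sits ortho to two methoxy groups, in compound 3 it does not.

Since the matching step gave a 1.1-fold lower number from compound 1 to compound 2 (0.04 log units; within the scatter) and compound 3 gives > 100000 nM, only a small step, a step that the limit leaves unreadable from compound 3 to compound 4, is expected for compound 4. In this assay compound 4 is therefore expected to give about 120000 nM, with a likely range from 50000 nM to 300000 nM.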

Compound 4, half-maximal inhibitory concentration: > 100000 nM
Compound 4: a limit, no number; the forecaster's own chance of this, stated with the estimate: 70%; the middle value does not contradict the limit.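

Compound 4, like compound 3, gives only a limit in this assay, so the step between them cannot be read: the limit of > 100000 nM in this assay, at which 2 of the 4 values shown sit.

The compounds shown leave open whether changing 4-methoxyphenyl to phenyl has any effect on the core of compound 3, and how weak either compound really is.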